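Swapping Bromo for Methyl on the Shared Core

The source may report more compounds than this note shows. Statements on the series, on what has been measured and on what is new or still open speak of the compounds shown alone.

Of the compounds shown here, three with the same core have been measured. In a functional assay on L1210 cells (Mus musculus) for inhibition (a higher number here means a weaker inhibitor, a lower number a stronger inhibitor), compound 1 `O=C1CCCCC/C1=C\c1ccccc1`, with no group on its aromatic ring, gives 261000 nM. Compound 2 `O=C1CCCCC/C1=C\c1ccc(Cl)cc1`, carrying chloro, gives 83000 nM, and compound 3 `O=C1CCCCC/C1=C\c1ccc(Br)cc1`, carrying bromo, gives 68400 nM. Exchanging chloro for bromo gives a 1.2-fold lower number from compound 2 to compound 3 (0.08 log units; within the scatter), so these two sit level, and both stand below compound 1.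

Compound 4 `Cc1ccc(/C=C2\CCCCCC2=O)cc1` has not been measured. Its change is methyl in place of bromo on an aromatic carbon. Among the measured compounds shown here, no measured step makes this exact swap. The nearest evidence is what adding each halogen did: a 3.1-fold lower number from compound 1 to compound 2 (0.50 log units; beyond the scatter) and a 3.8-fold lower number from compound 1 to compound 3 (0.58 log units; beyond the scatter). Both steps are modest, and the data do not show whether methyl behaves more like hydrogen or like these halogens. A small upward move in this assay is therefore expected, landing between the bromo and unsubstituted values: a 1.8-fold higher number from compound 3 to compound 4 (0.24 log units; within the scatter). For compound 4 the estimate is 120000 nM, with an expected range from 60000 nM to 230000 nM.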

Compound 4, half-maximal inhibitory concentration: > 500000 nM
Compound 4 gave a limit, no number; the forecaster's own chance of this, stated with the estimate: 5%; middle value at least 4.1-fold (0.61 log units) away from the limit.
By their numbers in this assay, from the lowest: compounds 3 and 2 (each within the scatter of the next); then compound 1. At a limit, above all of these: compound 4.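

Compound 4 gives only a limit in this assay, not a number: the limit of > 500000 nM in this assay, at which 1 of the 4 values shown sits.

At this place on the aromatic ring, the result shows that exchanging a halogen for methyl does not keep the lower numbers seen with chloro and bromo, with an at least 7.3-fold higher number from compound 3 to compound 4 (0.86 log units; beyond the scatter) and an at least 6.0-fold higher number from compound 2 to compound 4 (0.77 log units; beyond the scatter). Bromo and methyl each count one heavy atom, with no hydrogen-bond donors or acceptors and no net charge, so these counts do not separate the two groups.

Going by these compounds, whether methyl differs from hydrogen here stays open, as the step reads an at least 1.9-fold higher number from compound 1 to compound 4 (0.28 log units; that floor lies within the scatter). Also open, on these data alone, is how a methoxy group, an amine or a carboxylic acid on the same aromatic carbon would read in this assay.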